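Swapping the amide side chain of a shared core

This account rests on a few compounds, and the source may have more. Where it says the series, first, only, none or still open, it means among the compounds named here.

Three compounds share one core and differ only in the group on the carbonyl carbon of the amide. Compound 1 `CCC(=O)N(Cc1ccc(OC)c(O)c1)c1cc(OC)c(OC)c(OC)c1` carries an ethyl there and gives 61 nM in a functional assay on HCT-116 cells (Homo sapiens) for inhibition, read by MTT assay, with a stated time of 48 h; on this read-out lower numbers stand for stronger inhibition and higher numbers for weaker inhibition. Compound 2 `C#CC(=O)N(Cc1ccc(OC)c(O)c1)c1cc(OC)c(OC)c(OC)c1` carries an ethynyl and gives 310 nM; the step of a 5.1-fold higher number from compound 1 to compound 2 (0.71 log units; beyond the scatter). Compound 3 `COc1ccc(CN(C(=O)CCCCCl)c2cc(OC)c(OC)c(OC)c2)cc1O` carries a 4-chlorobutyl and gives 220 nM; here a 3.6-fold higher number from compound 1 to compound 3 (0.56 log units; beyond the scatter), while a 1.4-fold lower number from compound 2 to compound 3 (0.15 log units; within the scatter). On these numbers compound 3 stands second highest of three, close to compound 2 and well apart from compound 1.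

Compound 4 `C/C=C/C(=O)N(Cc1ccc(OC)c(O)c1)c1cc(OC)c(OC)c(OC)c1` is the next member: prop-1-en-1-yl in place of 4-chlorobutyl on a carbonyl carbon. The measured steps all concern the same carbonyl position. Moving from an ethyl to an ethynyl gave a modest rise in the number, and lengthening the chain with a chlorine gave a modest rise as well, whereas the step between the latter two stayed within the scatter. A prop-1-en-1-yl is shorter than the 4-chlorobutyl it replaces yet, like the ethynyl, unsaturated, so little shift beyond the scatter is expected; compound 4 is therefore estimated at 150 nM, within 55 nM to 400 nM. The expected step of a 1.5-fold lower number from compound 3 to compound 4 (0.17 log units; within the scatter).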

Compound 4, half-maximal inhibitory concentration: 55 nM
The estimate for compound 4 lay 2.7-fold (0.44 log units) above the measured number; measured number inside the range.
By their numbers in this assay, from the lowest: compounds 4 and 1 (each within the scatter of the next); then compounds 3 and 2 (each within the scatter of the next).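

In this assay, putting prop-1-en-1-yl on the carbonyl carbon in place of 4-chlorobutyl gives a 4.0-fold lower number from compound 3 to compound 4 (0.60 log units; beyond the scatter) and putting it in place of ethynyl gives a 5.6-fold lower number from compound 2 to compound 4 (0.75 log units; beyond the scatter), so a shorter unsaturated group does not by itself keep the number high at this position. Set against the ethyl, the change gives a 1.1-fold lower number from compound 1 to compound 4 (0.04 log units; within the scatter) and leaves the two groups level, which shows that this position tolerates a double bond in the group while the ethynyl, also unsaturated, stands clearly apart from both. What lies behind these differences is not addressed by any measurement at hand.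

Compound 3 changes both chain length and chlorine at once compared with compound 1, so a plain butyl would be needed to tell which of the two goes with its higher number. From the compounds shown here alone, how a ring such as cyclopropyl, an amine-bearing chain, or the opposite geometry of the prop-1-en-1-yl double bond would read at this carbonyl carbon also stays open.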